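The compounds below may be only part of what the source reports. "The series", "measured", "known", "first", "only" and "open" are said of these compounds alone.

Compound 1 `CC(=O)c1c(NNc2cc(C)c3ccccc3n2)cc(C)oc1=O` and compound 2 `Cc1cc2nn(-c3ccccc3)c(C)c2c(=O)o1` form the measured pair of this series. In a functional assay on the whole organism for inhibition, with Rattus norvegicus as the target, read by paw edema, with a stated time of 3 h, at a dose of 50 mg/kg (on this read-out higher numbers stand for more inhibition at the one dose given (going by the name of the read-out) and lower numbers for less inhibition), compound 1 gives 55.6% and compound 2 gives 52.5%. Among the compounds with values here, on these two numbers compound 2 stands lowest, with compound 1 as its only neighbour, and the gap between the two lies within the scatter. Compound 3 `Cc1ccc(-n2nc3cc(C)oc(=O)c3c2C)cc1` is the next member; against compound 2 the change is methyl in place of hydrogen on an aromatic carbon. Within the data shown here, with no measured step to lean on, only a step within the scatter is expected, in no set direction, so a number 0.5 percentage points lower from compound 2 to compound 3 (within the scatter) is the estimated shift. For compound 3 the expected reading is 52%, between 38% and 66%.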

Compound 3, a percentage reported as inhibition, in the whole organism at one dose (the size of the read-out at that dose, not a potency): 54%
Compound 3: middle estimate off by 2 percentage points, on the low side; the measured number falls inside the stated range.
By their numbers in this assay, from the lowest: compounds 2, 3 and 1 (each within the scatter of the next).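

In this assay, within the data shown here, methyl in place of hydrogen on the six-membered aromatic ring of carbon only, para to a large group, gives a number 1.5 percentage points higher from compound 2 to compound 3 (within the scatter), the first step that differs in one place. This place therefore takes a methyl without a step beyond the scatter. No data at hand bear on the origin of this step.
Going by these compounds, whether an amine, a carboxylic acid, a methoxy group or a longer chain at this place gives a step beyond the scatter stays open. On these data alone, with readings at a single dose, potency also stays open.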